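The source may hold more compounds than are shown below. What is called first, only, known or untested is meant among the compounds shown, and "the series" means these compounds.

Values in a functional assay on MCF7 cells (Homo sapiens) for antiproliferative activity, read by MTT assay, with a stated time of 72 h; a lower number here means a stronger inhibitor, a higher number a weaker inhibitor:
- Compound 1 `C/C=C/C(=O)Nc1cccc(Oc2nc(Nc3cccc(OC)c3)nc3c2CSCC3)c1`: 23400 nM
- Compound 2 `CC/C=C/C(=O)Nc1cccc(Oc2nc(Nc3cccc(OC)c3)nc3c2CSCC3)c1`: 24200 nM
- Compound 3 `C=C(F)C(=O)Nc1cccc(Oc2nc(Nc3cccc(OC)c3)nc3c2CSCC3)c1`: > 50000 nM, a limit of the assay

For the measured compounds named here, compound 1 holds one of only two numeric values in the set, and the other lies close to it: a 1.0-fold higher number from compound 1 to compound 2 (0.01 log units; within the scatter). The third result is a limit and gives no number: the limit of > 50000 nM in this assay, at which 1 of the 3 values shown sits.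

Compound 4 `C/C=C/C(=O)Nc1cccc(Oc2nc(Nc3ccc(OC)nc3)nc3c2CSCC3)c1` keeps the prop-1-en-1-yl on the carbonyl carbon and the shared core of compound 1. Going by the values given here, the single change is 6-methoxypyridin-3-yl in place of 3-methoxyphenyl on a nitrogen on an aromatic ring.

Among the compounds with values here, no measured pair differs at this place, so the evidence is indirect. All measured steps lie on the carbonyl side of the molecule. Beyond the step to compound 2, which stays within the scatter, there are an at least 2.1-fold higher number from compound 1 to compound 3 (0.32 log units; beyond the scatter) and an at least 2.0-fold higher number from compound 2 to compound 3 (0.31 log units; beyond the scatter). Both of these end at the limit, so their true size is open.

No step beyond the scatter is therefore expected in this assay, and no direction is favoured. The expected step is a 1.0-fold higher number from compound 1 to compound 4 (0.01 log units; within the scatter). Within the data shown here, with no direct precedent, the range is kept wide. Compound 4 is estimated at 24000 nM, with an expected range of 9000 nM to 50000 nM.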

Compound 4, half-maximal inhibitory concentration: 21100 nM
Estimate against measurement, compound 4: 1.1-fold (0.06 log units) above, and the stated range covers the measured number.
By their numbers in this assay, from the lowest: compounds 4, 1 and 2 (each within the scatter of the next). At a limit, above all of these: compound 3.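

In this assay, the change of 3-methoxyphenyl to 6-methoxypyridin-3-yl on the nitrogen on an aromatic ring gives a 1.1-fold lower number from compound 1 to compound 4 (0.04 log units; within the scatter). For the compounds shown here, the earlier compounds carried steps only on the carbonyl side of the molecule, so this is the first direct reading at this place: a ring carbon exchanged for a ring nitrogen, with one more hydrogen-bond acceptor counted on the group, gives no step beyond the scatter, and compound 4 keeps a numeric value. Nothing in the data shown accounts for this result or gives a cause for it.

From the compounds shown here alone, this reading rests on a single pair, with the prop-1-en-1-yl on the carbonyl carbon and the shared core held fixed, so it remains open whether the same exchange would also leave compound 2 unmoved, or would change the outcome for compound 3, whose result is a limit. Also open, going by these compounds, is whether this place responds to a larger change, such as an ethoxy group or a dimethylamino group in place of the methoxy, or a carboxylic acid on the ring.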